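Ethoxy for methyl: one change repeated across two cores

This account rests on a few compounds, and the source may have more. Where it says the series, first, only, none or still open, it means among the compounds named here.

Measured so far:
compound 1 `COc1cc(C(=O)c2sc3ccccc3c2-c2ccc(C)cc2)cc(OC)c1OC` — 3300 nM
compound 2 `CCOc1ccc(-c2c(C(=O)c3cc(OC)c(OC)c(OC)c3)sc3ccccc23)cc1` — 4100 nM
compound 3 `COc1cc(C(=O)c2sc3cc(C)ccc3c2Nc2ccc(C)cc2)cc(OC)c1OC` — 2500 nM

All three values come from a functional assay on Jurkat cells (Homo sapiens) for antiproliferative activity, read by MTT assay, with a stated time of 72 h; a lower number here means a stronger inhibitor, a higher number a weaker inhibitor. Compound 1 and compound 2 share one core and differ only by ethoxy in place of methyl on an aromatic carbon. That change gave a 1.2-fold higher number from compound 1 to compound 2 (0.09 log units; within the scatter), so within this pair the ethoxy and the methyl compound cannot be told apart. Compound 3 carries a different core; the difference between the two cores is not broken down here, and its value stands within the scatter of both compound 1 and compound 2, so no order among the three measured compounds is supported.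

Compound 4 `CCOc1ccc(Nc2c(C(=O)c3cc(OC)c(OC)c(OC)c3)sc3cc(C)ccc23)cc1` is not yet measured. It differs from compound 3 by ethoxy in place of methyl on an aromatic carbon, the same change that separates compound 2 from compound 1, made at the same kind of place on the aromatic ring in both pairs. Where the cut is taken one bond further out, the change in compound 3 to compound 4 reads (4-methylphenyl)amino to (4-ethoxyphenyl)amino rather than 4-methylphenyl to 4-ethoxyphenyl, since the pendant ring in this core is attached through the amino group. For the measured compounds named here, with only one earlier instance, the expectation rests entirely on that step: because a 1.2-fold higher number from compound 1 to compound 2 (0.09 log units; within the scatter) lay within the scatter, the step from compound 3 to compound 4 is expected to be a 1.2-fold higher number from compound 3 to compound 4 (0.08 log units; within the scatter). Compound 4 is therefore estimated at 3000 nM, with a range from 1500 nM to 6500 nM.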

Compound 4, half-maximal inhibitory concentration: 5000 nM
Compound 4: middle estimate off by 1.7-fold (0.22 log units), on the low side, within the range that was stated.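

Ethoxy in place of methyl on an aromatic carbon now stands on two cores in this assay, and the new step, a 2.0-fold higher number from compound 3 to compound 4 (0.30 log units; within the scatter), cannot be separated from the earlier one: the same change on two cores in this assay, a 1.2-fold higher number (0.09 log units; within the scatter) from compound 1 to compound 2 and a 2.0-fold higher number (0.30 log units; within the scatter) from compound 3 to compound 4, 1.6-fold (0.21 log units) apart, within the scatter of two such steps Within these two pairs, then, nothing indicates that the outcome of the change depends on the core, and neither step separates the ethoxy compound from its methyl partner. This does not show that the two cores respond alike or that the change is without effect on either core; two pairs in one assay, each step within the scatter, can establish neither point.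

The compounds shown leave open whether a longer chain such as propoxy or butoxy, or a group of another kind such as an amine or a carboxylic acid, on the same aromatic carbon would give a step beyond the scatter on either core. They also leave open what each structural difference between the cores contributes, as the core of compound 1 and the core of compound 3 differ in more than one place.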